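This account rests on a few compounds, and the source may have more. Where it says the series, first, only, none or still open, it means among the compounds named here.

In an assay on U2OS cells for activation of nuclear factor erythroid 2-related factor 2 (Homo sapiens), read by beta-arrestin recruitment, with a stated time of 6 h (on this read-out lower numbers stand for an effect already at smaller amounts and higher numbers for an effect only at larger amounts of compound), the measured compounds stand as follows:
compound 1 `O=S(=O)(/C=C/c1ccc(Cl)nc1)c1cccc(F)c1` gives 4870 nM
compound 2 `O=S(=O)(/C=C\c1ccc(Cl)nc1)c1cccc(F)c1` gives 965 nM
compound 3 `O=S(=O)(/C=C/c1ccc(Cl)nc1)c1cccc(Cl)c1` gives 2210 nM

Compound 3 holds the second highest of the three numbers; compound 1 sits one step above it and compound 2 one step below it. Compound 4 `O=S(=O)(/C=C\c1ccc(Cl)nc1)c1cccc(Cl)c1` is not yet measured. Its difference from compound 3 is the two compounds have the same atoms and bonds and differ only in configuration as drawn: 1 of 1 stereo elements differ; a double bond is drawn E in compound 3 and Z in compound 4. The step that bears on it is a 5.0-fold lower number from compound 1 to compound 2 (0.70 log units; beyond the scatter), the same change in configuration as drawn, because of the fact that compounds 1 and 2 differ only in the configuration as drawn. Carried over to compound 3, a step of similar size and direction is expected, so compound 4 is estimated at 450 nM, between 180 nM and 1100 nM. That amounts to an expected 4.9-fold lower number from compound 3 to compound 4 (0.69 log units; beyond the scatter).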

Compound 4, half-maximal effective concentration: 3390 nM
The estimate for compound 4 lay 7.5-fold (0.88 log units) below the measured number; measured number above the stated range.
By their numbers in this assay, from the lowest: compound 2; then compounds 3, 4 and 1 (each within the scatter of the next, the first and the last beyond it).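

In this assay, the change from E to Z at the double bond does not carry over between the fluoro and chloro compounds: a 5.0-fold lower number from compound 1 to compound 2 (0.70 log units; beyond the scatter) stands against a 1.5-fold higher number from compound 3 to compound 4 (0.19 log units; within the scatter). Chloro in place of fluoro also behaves differently with the Z double bond, where the result is a 3.5-fold higher number from compound 2 to compound 4 (0.55 log units; beyond the scatter) and the direction is opposite to that seen with the E double bond. Across these four compounds the two changes therefore do not act independently: the same change on two cores in this assay, a 2.2-fold lower number (0.34 log units; beyond the scatter) from compound 1 to compound 3 and a 3.5-fold higher number (0.55 log units; beyond the scatter) from compound 2 to compound 4, 7.7-fold (0.89 log units) apart, beyond the scatter of two such steps.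

The compounds leave open whether this dependence extends to other groups at this place, such as bromo, methoxy or an amine. They also do not show why the configuration of the double bond matters with fluoro but not with chloro.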